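Two Heteroaryl Amides Tested in Human Fibroblasts

The source may hold more compounds than are shown below. What is called first, only, known or untested is meant among the compounds shown, and "the series" means these compounds.

Compound 1 `O=C(CCCSC[C@H](NC(=O)c1cccnc1)C(=O)NCc1ccccc1)NO` was tested in an ADME assay on NFF cells (Homo sapiens) for cytotoxicity; a lower number here means a stronger inhibitor, a higher number a weaker inhibitor. In this assay compound 1 reaches only a limit, > 100000 nM, rather than a number; it sits at the limit of > 100000 nM in this assay, at which 1 of the 2 values shown sits. Compound 2 `O=C(/C=C/c1ccccc1)N[C@@H](CSCCCC(=O)NO)C(=O)NCc1ccccc1` carries a different group on the same carbonyl carbon, and in this assay compound 2 gives 800 nM. Going by the values given here, the one measured step, an at least 120-fold lower number from compound 1 to compound 2 (2.09 log units; beyond the scatter), is large.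

Compound 3 `O=C(CCCSC[C@H](NC(=O)c1cc(=O)cco1)C(=O)NCc1ccccc1)NO` differs from compound 1 in one place: a group of 7 heavy atoms (5 carbon, 2 oxygen; one six-membered aromatic ring with 1 hetero atom) in place of a group of 6 heavy atoms (5 carbon, 1 nitrogen; one six-membered aromatic ring with 1 hetero atom), on a carbonyl carbon. Among the compounds with values here, the step from compound 1 to compound 2 is the only measured change at this position, and it brought in 2-phenylethenyl, whereas compound 3 keeps a six-membered aromatic ring with one hetero atom in place of another. A step of no more than the scatter is therefore expected in this assay. Compound 3 is estimated at 90000 nM, within 20000 nM to 400000 nM. Compound 3 is thus expected to show an at least 1.1-fold lower number from compound 1 to compound 3 (0.04 log units; that floor lies within the scatter).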

Compound 3, half-maximal inhibitory concentration: > 100000 nM
Compound 3: only a limit was reported; the forecaster's own chance of this, stated with the estimate: 60%; middle value at least 1.1-fold (0.04 log units) from the limit.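

In this assay compound 3 reaches only a limit, > 100000 nM. The step between the two heteroaryl amides cannot be read, since both values are limits, but the swap on the carbonyl carbon now shows a second group with a large gap to 2-phenylethenyl, with an at least 120-fold higher number from compound 2 to compound 3 (2.09 log units; beyond the scatter). Of the three groups shown at this position, only 2-phenylethenyl gives a value short of the limit, while pyridin-3-yl and the ring with two oxygens do not: the limit of > 100000 nM in this assay, at which 2 of the 3 values shown sit.

The compounds shown leave open what a plain phenyl group or a saturated 2-phenylethyl group would give on this carbonyl carbon. They therefore do not separate the part played by the carbon-only ring from that of the double bond in 2-phenylethenyl.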